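The compounds below may be only part of what the source reports. "The series", "measured", "known", "first", "only" and "open" are said of these compounds alone.

Measured so far:
compound 1, `CCCCCCNc1cnc(C(=O)NCc2ccccc2)cn1`: > 100000 nM
compound 2, `CCCCNc1cnc(C(=O)NCc2ccccc2)cn1`: > 100000 nM
compound 3, `CCCCCCCNc1nccnc1C(=O)NCc1ccccc1`: > 100000 nM

All three were tested in an ADME assay on HeLa cells (Homo sapiens) for cytotoxicity, read by microscopy, with a stated time of 6 days; a higher number here means that more compound is tolerated, a lower number that less compound is tolerated. For compound 1 the value > 100000 nM is a limit of the assay rather than a number. For compound 2 the value > 100000 nM is likewise a limit. For compound 3 the value > 100000 nM is a limit as well. Thus (the limit of > 100000 nM in this assay, at which 3 of the 3 values shown sit), and no compound shown has yet given a readable minimum cytotoxic concentration.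

Compound 1 and compound 2 share one core and differ in a single place: hydrogen in place of ethyl on a saturated chain carbon, four bonds along the chain from a nitrogen on an aromatic ring. The step that the two limits leave unreadable from compound 1 to compound 2 cannot be read, since both ends sit at the limit. Compound 3 carries a different core; how the two cores differ is not broken down here.

Compound 4, `CCCCCNc1nccnc1C(=O)NCc1ccccc1`, is not yet measured. It arises from compound 3 by hydrogen in place of ethyl on a saturated chain carbon, five bonds along the chain from a nitrogen on an aromatic ring. Among the compounds with values here, this is the same kind of change as the one from compound 1 to compound 2, though the place differs: there the carbon sat four bonds along the chain from a nitrogen on an aromatic ring, here five bonds along the chain.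

For compound 4 the step of a number no higher from compound 3 to compound 4 (the limit leaves the size open) is expected to be small, resting on the unreadable step that the two limits leave unreadable from compound 1 to compound 2 and on (the limit of > 100000 nM in this assay, at which 3 of the 3 values shown sit). Compound 4 is therefore estimated at 100000 nM, most likely again reported only as a limit.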

Compound 4, minimum cytotoxic concentration: > 100000 nM
Compound 4 was reported as a limit (the forecaster's own chance of this, stated with the estimate: 85%); the middle value lies on the limit itself.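

In this assay the step from compound 3 to compound 4 cannot be read, since both values are limits and not numbers, just as for compound 1 and compound 2: the limit of > 100000 nM in this assay, at which 4 of the 4 values shown sit. The compounds shown leave open at what concentration any of them harms the cells, and so whether the length of the chain has any effect on the minimum cytotoxic concentration.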